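Swapping One Group on a Thiocarbonyl-Linked Nitrogen

The source may hold more compounds than are shown below. What is called first, only, known or untested is meant among the compounds shown, and "the series" means these compounds.

Compound 1 `O=C(NC(=S)N1CCc2cccc(OCc3ccccc3)c21)c1ccccc1` and compound 2 `CC(C)(C)c1ccc(C(=O)NC(=S)N2CCc3c(OCCCCCOc4ccc(Cl)cc4)cccc32)cc1` were both tested in an ADME assay on Huh-7 cells (Homo sapiens) for cytotoxicity; a lower number here means that less compound is tolerated, a higher number that more compound is tolerated. There compound 1 reaches only the limit of > 50000 nM. Compound 2 likewise shows only the limit of > 50000 nM. Compound 2 therefore stands at the limit of > 50000 nM in this assay, at which 2 of the 2 values shown sit, and nothing beyond that point is known. Compound 3 `S=C(NC(=S)N1CCc2c(OCCCCCOc3ccc(Cl)cc3)cccc21)Oc1ccccc1` differs from compound 2 in one place: a group of 9 heavy atoms (7 carbon, 1 oxygen, 1 sulfur; one six-membered aromatic ring of carbon only) in place of a group of 12 heavy atoms (11 carbon, 1 oxygen; one six-membered aromatic ring of carbon only), on an amide-type nitrogen. Going by the values given here, no measured step of this kind exists, so no change beyond the scatter is expected. Compound 3 is estimated at 60000 nM, with a range from 25000 nM to 150000 nM. The expected step is a step that the limit leaves unreadable from compound 2 to compound 3, most likely again ending at the limit.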

Compound 3, half-maximal cytotoxic concentration: > 50000 nM
Compound 3 gave a limit, no number; the forecaster's own chance of this, stated with the estimate: 75%; the middle value lies beyond the limit too.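

In this assay compound 2 and compound 3 both give a limit, not a number, so the step between them cannot be read: the limit of > 50000 nM in this assay, at which 3 of the 3 values shown sit.

As far as these compounds go, whether replacing the (4-(tert-butyl)phenyl)carbonyl group changes how much compound the cells tolerate remains open.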